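The compounds below may be only part of what the source reports. "The series", "measured", "known", "first", "only" and "open" are said of these compounds alone.

Measured compounds:
Compound 1 `c1ccc(-c2cn3ccnc3c(-c3ccc4ncn(C5CCCCC5)c4c3)n2)cc1` gives 65.7% in a functional assay on UACC-62 cells (Homo sapiens) for inhibition, read by sulforhodamine B assay, with a stated time of 48 h, tested at 10 uM; on this read-out higher numbers stand for more inhibition at the one concentration tested (going by the name of the read-out) and lower numbers for less inhibition.
Compound 2 `COc1ccc(-c2cn3ccnc3c(-c3ccc4ncn(C5CCCCC5)c4c3)n2)cc1` gives 65.2% in this assay.
Compound 3 `Brc1ccc(-c2cn3ccnc3c(-c3ccc4ncn(C5CCCCC5)c4c3)n2)cc1` gives 46.9% in this assay.

Compound 3 stands lowest of the three numbers in this assay. Its nearest neighbour is compound 2, and the step of a number 18.3 percentage points lower from compound 2 to compound 3 (beyond the scatter) is beyond the scatter; the step of a number 18.8 percentage points lower from compound 1 to compound 3 (beyond the scatter) is beyond the scatter as well. By contrast, the step of a number 0.5 percentage points lower from compound 1 to compound 2 (within the scatter) stays within the scatter, so compound 1 and compound 2 show nothing that separates them.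

Compound 4 `Fc1ccccc1-c1cn2ccnc2c(-c2ccc3ncn(C4CCCCC4)c3c2)n1` has not yet been measured in this assay. The change from compound 3 is 2-fluorophenyl in place of 4-bromophenyl on an aromatic carbon. For the measured compounds named here, two measured steps bear on it, both of which brought bromo onto the phenyl ring: a number 18.8 percentage points lower from compound 1 to compound 3 (beyond the scatter) and a number 18.3 percentage points lower from compound 2 to compound 3 (beyond the scatter). The change to compound 4 removes that bromo, so the part of those steps that can be read backwards points upward. Going by the values given here, no measured step speaks to fluoro or to the 2-position of the phenyl ring, so the size of that part is unknown. Compound 4 is therefore expected to recover some of the loss, with a step of a number 10.1 percentage points higher from compound 3 to compound 4 (beyond the scatter) upward but short of the full return. The estimate for compound 4 in this assay is 57%, with a range from 40% to 72%.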

Compound 4, a percentage reported as inhibition, at one concentration (the size of the read-out at that concentration, not a potency): 38.2%
The estimate for compound 4 lay 18.8 percentage points above the measured number, and the stated range ends above it.
By their numbers in this assay, from the lowest: compounds 4 and 3 (each within the scatter of the next); then compounds 2 and 1 (each within the scatter of the next).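

In this assay, the step of a number 27.5 percentage points lower from compound 1 to compound 4 (beyond the scatter) shows that a fluoro group on the phenyl ring at this position also lowers the number, so the loss is not confined to bromo, and the step of a number 27 percentage points lower from compound 2 to compound 4 (beyond the scatter) shows that 2-fluorophenyl likewise falls short of 4-methoxyphenyl. The step of a number 8.7 percentage points lower from compound 3 to compound 4 (within the scatter) leaves 2-fluorophenyl and 4-bromophenyl with nothing that separates them, so taking away the bromo did not by itself restore the number of the plain phenyl compound. Among these four compounds, the two that carry a halogen both lie beyond the scatter below the two that do not, and no compound goes against this, but nothing available explains it.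

The halogen and its ring position change together between compound 3 and compound 4, so 4-fluorophenyl and 2-bromophenyl would be needed to tell which of the two matters at this position. From the compounds shown here alone, it also remains open whether the low numbers extend to a chloro group, and how an amine or a carboxylic acid on the phenyl ring would compare with the plain phenyl and 4-methoxyphenyl compounds.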